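Guanylhydrazones on two fused cores: a thiophene swap

A few compounds are considered here, and "the series" means these few. Any claim that something is new, unique, unknown or untested is made for them only; others in the source may bear on it.

Measured so far:
- compound 1 `N=C(N)N/N=C/c1c(-c2cccs2)nc2sccn12` — 15100 nM
- compound 2 `Cc1cc(-c2nc3sccn3c2/C=N/NC(=N)N)c(C)s1` — 16200 nM
- compound 3 `Cc1cc(-c2nc3n(c2/C=N/NC(=N)N)CCS3)c(C)s1` — 15500 nM

All three were run in a functional assay on cells (Melanoma cell, Homo sapiens) for inhibition; on this read-out lower numbers stand for stronger inhibition of growth and higher numbers for weaker inhibition of growth. Compound 1 gives 15100 nM, compound 2 gives 16200 nM and compound 3 gives 15500 nM; the three numbers lie within the scatter of one another, so no ordering among them is claimed.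

Going by the values given here, the one step that is broken down is thiophen-2-yl in place of 2,5-dimethylthiophen-3-yl on an aromatic carbon, which produced a 1.1-fold lower number from compound 2 to compound 1 (0.03 log units; within the scatter). Compound 2 and compound 3 carry different cores, and the difference between the two cores is not broken down here; their values in this assay nonetheless sit within the scatter of each other.

Compound 4 `N=C(N)N/N=C/c1c(-c2cccs2)nc2n1CCS2` is not yet measured. It differs from compound 3 by thiophen-2-yl in place of 2,5-dimethylthiophen-3-yl on an aromatic carbon. This is the same kind of change as the step from compound 2 to compound 1, not the same: around the place, the change on the core of compound 3 additionally lies two ring bonds from two ring atoms that each bear a fused ring, which is not part of the description for the change on the core of compound 2.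

Given that the same kind of change gave a 1.1-fold lower number from compound 2 to compound 1 (0.03 log units; within the scatter), the expected step from compound 3 to compound 4 is a 1.1-fold lower number from compound 3 to compound 4 (0.03 log units; within the scatter), a step within the scatter. For compound 4 in this assay the estimate is 14500 nM, with a range from 7000 nM to 30000 nM.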

Compound 4, concentration for 50% growth inhibition: 21400 nM
Compound 4: the middle estimate sits 1.5-fold (0.17 log units) below what was measured; measured number inside the range.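

Thiophen-2-yl in place of 2,5-dimethylthiophen-3-yl on an aromatic carbon gives, in this assay, a 1.4-fold higher number from compound 3 to compound 4 (0.14 log units; within the scatter) and so leaves no readable effect of the swap on the core of compound 3. Carried from one core to the other, the change stays a step that cannot be told from no change on either core, and the two steps do not differ: the same change on two cores in this assay, a 1.1-fold lower number (0.03 log units; within the scatter) from compound 2 to compound 1 and a 1.4-fold higher number (0.14 log units; within the scatter) from compound 3 to compound 4, 1.5-fold (0.17 log units) apart, within the scatter of two such steps. Going by these compounds alone, with only one pair on each core, this does not show that the swap is truly without effect, nor that a change giving a step beyond the scatter would carry between the two cores in the same way.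

The compounds shown hold only these two thiophene groups at this place, so it stays open whether a phenyl ring, an amine or a longer alkyl chain on the same aromatic carbon would move the number beyond the scatter on either core. Also open, as far as these compounds go, is whether replacing the guanylhydrazone side chain with a group such as a carboxylic acid or a simple amide would change the read-out on either core.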